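This account rests on a few compounds, and the source may have more. Where it says the series, first, only, none or still open, it means among the compounds named here.

Measured so far in an assay on HEK293 cells for antagonist activity at P2X purinoceptor 7 (Homo sapiens), read by fluorescence, with a stated time of 2 h; on this read-out lower numbers stand for stronger inhibition and higher numbers for weaker inhibition:
compound 2 `O=C(c1ccc(Cl)c(C(F)(F)F)c1)N1CCC(n2cncc2-c2ccc(OS(=O)(=O)c3cccc4ccccc34)cc2)CC1` — 3520 nM
compound 1 `O=C(Oc1ccc(-c2cncn2C2CCN(C(=O)c3ccc(Cl)c(C(F)(F)F)c3)CC2)cc1)c1cccs1` — > 10000 nM

Within the data shown here, compound 2 gives the only real number, 3520 nM in this assay. Compound 1 reaches only a limit, > 10000 nM (the limit of > 10000 nM in this assay, at which 1 of the 2 values shown sits). Compound 3 `O=C(c1ccc(Cl)c(C(F)(F)F)c1)N1CCC(n2cncc2-c2ccc(OS(=O)(=O)c3cccc([N+](=O)[O-])c3)cc2)CC1` has not been measured. It differs from compound 2 by 3-nitrophenyl in place of naphthalen-1-yl on a sulfonyl sulfur. Among the measured compounds shown here, no measured pair shows what such a swap does here, so the change is expected to be modest, leaning toward weaker inhibition, a 1.7-fold higher number from compound 2 to compound 3 (0.23 log units; within the scatter). Compound 3 is therefore estimated at 6000 nM, somewhere between 1500 nM and 25000 nM.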

Compound 3, half-maximal inhibitory concentration: 249 nM
Compound 3: middle estimate off by 24-fold (1.38 log units), on the high side; the measured number lies below the stated range.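

Putting 3-nitrophenyl in place of naphthalen-1-yl on the sulfonyl sulfur gives a 14-fold lower number from compound 2 to compound 3 (1.15 log units; beyond the scatter), so activity here responds strongly to the group on that sulfur. Compound 1 stands at a limit of the assay, not at a real number: the limit of > 10000 nM in this assay, at which 1 of the 3 values shown sits. Replacing its (thiophen-2-yl)carbonyl on the oxygen with (3-nitrophenyl)sulfonyl gives an at least 40-fold lower number from compound 1 to compound 3 (1.60 log units; beyond the scatter).

The swap from compound 2 removes an aromatic ring and adds a nitro group at once, and the compounds shown cannot separate these two changes. A plain phenyl or a 3-cyanophenyl on the sulfonyl sulfur would help to tell them apart.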